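Chloro for methyl on two cores: growth inhibition notes

A few compounds are considered here, and "the series" means these few. Any claim that something is new, unique, unknown or untested is made for them only; others in the source may bear on it.

Measured compounds, in a functional assay on NCI-H226 cells (Homo sapiens) for inhibition, read by MTT assay, with a stated time of 72 h; a lower number here means a stronger inhibitor of growth, a higher number a weaker inhibitor of growth:

Compound 1 `Cc1ccc(-c2cc(N)n(-c3ccc(Br)cc3)n2)cc1`: 54300 nM
Compound 2 `Nc1cc(-c2ccc(Cl)cc2)nn1-c1ccc(Br)cc1`: 58700 nM
Compound 3 `Cc1ccc(-c2nn(-c3ccc(Br)cc3)c(/N=C/N(C)C)c2C=O)cc1`: 8200 nM

Compounds 1 and 2 share one core and differ in a single place:

chloro in place of methyl on an aromatic carbon

This change gave a 1.1-fold higher number from compound 1 to compound 2 (0.03 log units; within the scatter), so the two numbers are not separable in this assay.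

Compound 3 carries a second core. How the two cores differ is not broken down here. Compound 3 gives the lowest number of the three, and its gaps to compound 1 and to compound 2 are both beyond the scatter.

Compound 4 `CN(C)/C=N/c1c(C=O)c(-c2ccc(Cl)cc2)nn1-c1ccc(Br)cc1` is not yet measured. It stands to compound 3 as compound 2 stands to compound 1:

chloro in place of methyl on an aromatic carbon

The place of the change reads the same in both pairs, so this is the same change made on the second core.

On the first core the change was flat, with a 1.1-fold higher number from compound 1 to compound 2 (0.03 log units; within the scatter). For the measured compounds named here, the only basis for compound 4 is that step, and it is expected to carry over: the step from compound 3 to compound 4 is estimated at a 1.1-fold higher number from compound 3 to compound 4 (0.04 log units; within the scatter). Compound 4 is therefore expected to give about 9000 nM, with a range of 4000 nM to 20000 nM, because compound 3 gives 8200 nM and the same change on the first core gave a 1.1-fold higher number from compound 1 to compound 2 (0.03 log units; within the scatter). The range is widened somewhat since the change is seen on one core only.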

Compound 4, concentration for 50% growth inhibition: 62900 nM
Compound 4: middle estimate off by 7.0-fold (0.84 log units), on the low side, outside the stated range (above it).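

In this assay, the change from 4-methylphenyl to 4-chlorophenyl does not carry over as a fixed step within this series: on the second core it gives a 7.7-fold higher number from compound 3 to compound 4 (0.88 log units; beyond the scatter), whereas it was flat on the first core. The result from one core therefore cannot be used as a size for the other, and the two steps are separable: the same change on two cores in this assay, a 1.1-fold higher number (0.03 log units; within the scatter) from compound 1 to compound 2 and a 7.7-fold higher number (0.88 log units; beyond the scatter) from compound 3 to compound 4, 7.1-fold (0.85 log units) apart, beyond the scatter of two such steps

This shows that the effect of the change depends on the core that carries it, but it does not show which part of the second core matters or why, and with one pair per core no rule for further cores can be drawn from it.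

Still open, on these data alone, is whether the dependence belongs to chloro and methyl alone or also appears with other groups in the same place, such as fluoro, methoxy or trifluoromethyl. For the compounds shown here, also open is whether the carbonyl or the dimethylamino-bearing imine chain of the second core governs the step, which pairs holding only one of these two groups, or a simple amide in place of the carbonyl, could separate.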